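Diacylhydrazine series: aryl variation on the hydrazide carbonyl

A few compounds are considered here, and "the series" means these few. Any claim that something is new, unique, unknown or untested is made for them only; others in the source may bear on it.

Measured so far:
compound 1 `COc1cccc(C(=O)NN(C(=O)c2ccccc2Cl)C(C)(C)C)c1` — 52.5 nM
compound 2 `CC(C)(C)N(NC(=O)c1cccc(Cl)c1Cl)C(=O)c1ccccc1Cl` — 9.33 nM

Among the compounds with values here, in an assay on cells for agonist activity at ecdysone receptor (Bombyx mori), read by a luciferase reporter, with a stated time of 24 h (on this read-out higher numbers stand for an effect only at larger amounts of compound and lower numbers for an effect already at smaller amounts), compound 2 gives the lowest of the two numbers; its only neighbour, compound 1, sits at a 5.6-fold lower number from compound 1 to compound 2 (0.75 log units; beyond the scatter). Compound 3 `Cc1ccc(C)c(C(=O)NN(C(=O)c2ccccc2Cl)C(C)(C)C)c1` carries 2,5-dimethylphenyl in place of 2,3-dichlorophenyl on a carbonyl carbon. Within the data shown here, the one step that bears on this position, the exchange of 3-methoxyphenyl for 2,3-dichlorophenyl, was a 5.6-fold lower number from compound 1 to compound 2 (0.75 log units; beyond the scatter), so this position clearly moves the read-out. The new aryl shares neither the chlorines of compound 2 nor the methoxy of compound 1, so the direction is uncertain; a partial loss is expected. For compound 3 an estimate of 22 nM (range 6 nM to 80 nM) is given, i.e. an expected 2.4-fold higher number from compound 2 to compound 3 (0.37 log units; beyond the scatter).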

Compound 3, half-maximal effective concentration: 1620 nM
Beside the measured number, compound 3's estimate is 74-fold (1.87 log units) below it; the whole stated range lies below it.
By their numbers in this assay, from the lowest: compound 2; then compound 1; then compound 3.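

In this assay, this position proves far more sensitive than the first step showed: 2,5-dimethylphenyl in place of 2,3-dichlorophenyl gives a 170-fold higher number from compound 2 to compound 3 (2.24 log units; beyond the scatter), and in place of 3-methoxyphenyl gives a 31-fold higher number from compound 1 to compound 3 (1.49 log units; beyond the scatter). The leaving and entering groups match in heavy-atom count, ring type and hydrogen-bond donor and acceptor counts, so these counts do not account for the large step. No supporting data bear on the origin of this change.

The compounds shown leave open whether the step follows the exchange of chlorine for methyl or the substitution pattern. A 2,5-dichlorophenyl or 2,3-dimethylphenyl group on the same carbonyl carbon would separate the two.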